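A Thiophene Replaces the Pyridine of Compound 3

The source may hold more compounds than are shown below. What is called first, only, known or untested is meant among the compounds shown, and "the series" means these compounds.

Of the compounds shown here, three sharing one core have been tested in an assay on isolated protein for inhibition of acyl-CoA desaturase 1 (Rattus norvegicus); on this read-out lower numbers stand for stronger inhibition and higher numbers for weaker inhibition. Compound 2 `CS(=O)(=O)c1ccc2nc(-c3ccc(-c4ccc(F)cc4)cc3)[nH]c2c1` gives 25 nM. Compound 3 `CS(=O)(=O)c1ccc2nc(-c3ccc(-c4ccccn4)cc3)[nH]c2c1` gives 1710 nM. Compound 1 `Cc1ccc(-c2ccc(-c3nc4ccc(S(C)(=O)=O)cc4[nH]3)cc2)cc1` reaches only a limit of the assay, > 20000 nM, which is not a number. Of the two numbers, compound 3 sits highest; its nearest neighbour is compound 2, and the step from the one to the other was large: a 68-fold higher number from compound 2 to compound 3 (1.84 log units; beyond the scatter). The other step leading to compound 3 was also large: an at least 11-fold lower number from compound 1 to compound 3 (1.06 log units; beyond the scatter).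

Compound 4 `CS(=O)(=O)c1ccc2nc(-c3ccc(-c4ccsc4)cc3)[nH]c2c1` has not yet been measured. It differs from compound 3 in one place: thiophen-3-yl in place of pyridin-2-yl on an aromatic carbon. The thiophen-3-yl, like the 4-fluorophenyl of compound 2 and the 4-methylphenyl of compound 1, contains no nitrogen, so the step from compound 2 to compound 3 is the best guide, and it went strongly upward. Running that step back, a large downward move is expected, a 17-fold lower number from compound 3 to compound 4 (1.23 log units; beyond the scatter). Compound 4 is therefore estimated at 100 nM, within a range from 20 nM to 600 nM.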

Compound 4, half-maximal inhibitory concentration: 104 nM
Compound 4: middle estimate off by 1.0-fold (0.02 log units), on the low side; the measured number falls inside the stated range.
By their numbers in this assay, from the lowest: compound 2; then compound 4; then compound 3. At a limit, above all of these: compound 1.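

In this assay, the group on this aromatic carbon, para to a large group, need not be a six-membered ring: the five-membered thiophen-3-yl, with sulfur as its hetero atom, gives back most of what pyridin-2-yl lost, with a 16-fold lower number from compound 3 to compound 4 (1.22 log units; beyond the scatter). It does not fully match the 4-fluorophenyl, as there remains a 4.2-fold higher number from compound 2 to compound 4 (0.62 log units; beyond the scatter), a modest step but one beyond the scatter. Having no nitrogen in this ring is also not enough on its own, since the 4-methylphenyl of compound 1 also has none, and an at least 190-fold lower number from compound 1 to compound 4 (2.28 log units; beyond the scatter) rests on a limit of the assay rather than a number: the limit of > 20000 nM in this assay, at which 1 of the 4 values shown sits.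

On these data alone, whether a plain phenyl or a pyridin-3-yl on this carbon would land nearer compound 2 or nearer compound 3 remains open. So does the outcome for thiophen-2-yl or furan-3-yl, which would show how much the hetero atom and its place in the ring matter.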